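Moving a bromine around the phenyl ring

The source may hold more compounds than are shown below. What is called first, only, known or untested is meant among the compounds shown, and "the series" means these compounds.

Compound 1 `N#CC1=C(N)Oc2c(c3nc4ccccc4nc3c3ccccc23)C12C(=O)N(Cc1cnnn1-c1ccccc1Cl)c1ccccc12` and compound 2 `N#CC1=C(N)Oc2c(c3nc4ccccc4nc3c3ccccc23)C12C(=O)N(Cc1cnnn1-c1ccccc1Br)c1ccccc12` share one core and differ only in the halogen on the phenyl ring. In a functional assay on A549 cells (Homo sapiens) for antiproliferative activity, read by MTT assay, with a stated time of 48 h (a higher number here means a weaker inhibitor, a lower number a stronger inhibitor), compound 1 gives 42600 nM. For compound 2 this assay reports only a limit, > 50000 nM. The step of an at least 1.1-fold higher number from compound 1 to compound 2 (0.06 log units; that floor lies within the scatter) thus rests on the limit of > 50000 nM in this assay, at which 1 of the 2 values shown sits, and shows nothing beyond the scatter. Compound 2 therefore stands at the point where this assay no longer returns a number.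

Compound 3 `N#CC1=C(N)Oc2c(c3nc4ccccc4nc3c3ccccc23)C12C(=O)N(Cc1cnnn1-c1cccc(Br)c1)c1ccccc12` is not yet measured. It differs from compound 2 by 3-bromophenyl in place of 2-bromophenyl on an aromatic nitrogen. Within the data shown here, no measured step moves a group from one position of the phenyl ring to another; the only measured step swaps one halogen for another and stays within the scatter. The expected step that the limit leaves unreadable from compound 2 to compound 3 is therefore none beyond the scatter. For compound 3 the estimate in this assay is 55000 nM, within a range from 25000 nM to 150000 nM, and this assay may again report only a limit.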

Compound 3, half-maximal inhibitory concentration: > 50000 nM
Compound 3: only a limit was reported; the forecaster's own chance of this, stated with the estimate: 60%; the middle value lies beyond the limit too.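

In this assay, compound 3 also returns only a limit, so a bromine on the phenyl ring yields no number in either the 2-bromophenyl or the 3-bromophenyl form, and the step between these two compounds cannot be read: the limit of > 50000 nM in this assay, at which 2 of the 3 values shown sit.

Among these compounds, the one readable new step, an at least 1.1-fold higher number from compound 1 to compound 3 (0.06 log units; that floor lies within the scatter), gives only a floor, so 3-bromophenyl in place of 2-chlorophenyl shows nothing beyond the scatter. Among these three compounds, a measured number remains only for compound 1, at 42600 nM.

On these data alone, whether moving the bromine changes activity at all stays open, since any difference would lie past the limit of this assay. Also open, as far as these compounds go, is how a different group on this phenyl ring, such as an amine or a carboxylic acid, would behave in this assay.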